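The source may report more compounds than this note shows. Statements on the series, on what has been measured and on what is new or still open speak of the compounds shown alone.

In a functional assay on Raji cells (Homo sapiens) for inhibition, read by MTT assay, with a stated time of 96 h (on this read-out lower numbers stand for an effect already at smaller amounts and higher numbers for an effect only at larger amounts of compound), three compounds that share one core have been measured. Compound 1 `CC(C)Cn1c(=O)n(C)c(=O)c2nc(C(=O)N(C)CCCO)c(Cc3cccc4ccccc34)nc21` gives > 10000 nM, which is a limit of the assay and not a number. Compound 2 `CC(C)Cn1c(=O)n(C)c(=O)c2nc(CCCCCO)c(Cc3cccc4ccccc34)nc21` gives 58 nM. Compound 3 `CC(C)Cn1c(=O)n(C)c(=O)c2nc(-c3[nH]nnc3CCCO)c(Cc3cccc4ccccc34)nc21` gives 6020 nM, the higher of the two actual numbers, and the move to it is a 100-fold higher number from compound 2 to compound 3 (2.02 log units; beyond the scatter).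

Compound 4 `COCCCCCc1nc2c(=O)n(C)c(=O)n(CC(C)C)c2nc1Cc1cccc2ccccc12` differs from compound 3 at a single place: 5-methoxypentyl in place of 4-(3-hydroxypropyl)-1H-1,2,3-triazol-5-yl on an aromatic carbon. The new 5-methoxypentyl sits on an aromatic carbon, ortho to a (naphthalen-1-yl)methyl group.

Among the compounds with values here, two measured steps bear on this change. Going to the 5-hydroxypentyl chain gave an at least 170-fold lower number from compound 1 to compound 2 (2.23 log units; beyond the scatter), and leaving that chain for the 4-(3-hydroxypropyl)-1H-1,2,3-triazol-5-yl group gave a 100-fold higher number from compound 2 to compound 3 (2.02 log units; beyond the scatter). Both are large, and both favour the open pentyl chain. Compound 4 has that chain too, so it should behave more like compound 2 at 58 nM than like compound 3. However, no measured step covers 5-methoxypentyl in place of 5-hydroxypentyl, so some loss against compound 2 remains possible. A large fall in the number is therefore expected in this assay, with an expected size of a 60-fold lower number from compound 3 to compound 4 (1.78 log units; beyond the scatter). Compound 4 is estimated at 100 nM, with an expected range from 25 nM to 600 nM.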

Compound 4, half-maximal effective concentration: 5780 nM
Estimate against measurement, compound 4: 58-fold (1.76 log units) below; the measured number lies above the stated range.
By their numbers in this assay, from the lowest: compound 2; then compounds 4 and 3 (each within the scatter of the next). At a limit, above all of these: compound 1.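

In this assay, within the data shown here, methyl in place of hydrogen on the oxygen of the 5-hydroxypentyl chain gives a 100-fold higher number from compound 2 to compound 4 (2.00 log units; beyond the scatter), which shows that the open chain is not enough on its own at this aromatic carbon; the earlier compounds could not separate the chain from the hydroxyl at its end. The step of a 1.0-fold lower number from compound 3 to compound 4 (0.02 log units; within the scatter) also places two very different groups together, since 5-methoxypentyl has no ring and 4-(3-hydroxypropyl)-1H-1,2,3-triazol-5-yl holds a five-membered aromatic ring, so among the compounds shown only the 5-hydroxypentyl group of compound 2 stands apart from these two. Compound 1 is held at a limit, so its comparison reads only as an at least 1.7-fold lower number from compound 1 to compound 4 (0.23 log units; that floor lies within the scatter) and gives no order: the limit of > 10000 nM in this assay, at which 1 of the 4 values shown sits.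

The compounds shown leave open whether the hydroxyl hydrogen itself matters or whether any added group on that oxygen would give the same result, which a plain pentyl chain with no oxygen, or an ethyl ether, could help to settle. As far as these compounds go, what an amine or a carboxylic acid at the end of the chain would give is equally open, as is the effect of a longer chain ending in hydroxyl.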